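The compounds below may be only part of what the source reports. "The series", "measured", "known", "first", "only" and "open" are said of these compounds alone.

Values in a functional assay on A549 cells (Homo sapiens) for antiproliferative activity; a lower number here means a stronger inhibitor of growth, a higher number a weaker inhibitor of growth:

- compound 1 `c1ccc(-c2cc(-c3cccnc3)nc(-c3ccccn3)c2)cc1`: 44.8 ug/mL
- compound 2 `c1ccc(-c2cc(-c3ccsc3)cc(-c3ccccn3)n2)nc1`: 0.62 ug/mL
- compound 3 `c1ccc(-c2cc(-c3ccccn3)nc(-c3ccccn3)c2)cc1`: 0.56 ug/mL

Compound 2 sits with compound 3 at the low end of this small set, a 1.1-fold lower number from compound 2 to compound 3 (0.04 log units; within the scatter). Compound 1 stands well apart at the high end, and its value of 44.8 ug/mL compares with 0.62 ug/mL for compound 2.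

The next comparison is with compound 4 `c1ccc(-c2cc(-c3ccsc3)cc(-c3cccnc3)n2)nc1`, still unmeasured in this assay. The change is pyridin-3-yl in place of pyridin-2-yl on an aromatic carbon of a six-membered aromatic ring with 1 nitrogen, next to the ring nitrogen.

For the measured compounds named here, only one measured step speaks directly to this exchange, and it runs in the reverse direction: an 80-fold lower number from compound 1 to compound 3 (1.90 log units; beyond the scatter), pyridin-2-yl in place of pyridin-3-yl. That pair carries phenyl where compound 2 carries thiophen-3-yl. Going by the values given here, the swap between those two groups was silent in the one pair that shows it, a 1.1-fold lower number from compound 2 to compound 3 (0.04 log units; within the scatter), so the large step may carry over, though it rests on a single pair. A large rise in the number is therefore expected, possibly somewhat smaller than the precedent. The expected step is a 48-fold higher number from compound 2 to compound 4 (1.68 log units; beyond the scatter), beyond the scatter. Compound 4 is estimated at 30 ug/mL, with an expected range of 6 ug/mL to 90 ug/mL.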

Compound 4, concentration for 50% growth inhibition: > 100 ug/mL
Compound 4 was reported as a limit; the forecaster's own chance of this, stated with the estimate: 5%; at least 3.3-fold (0.52 log units) between middle value and limit.
By their numbers in this assay, from the lowest: compounds 3 and 2 (each within the scatter of the next); then compound 1. At a limit, above all of these: compound 4.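

Compound 4 is reported only as a limit, > 100 ug/mL, in this assay. Pyridin-3-yl in place of pyridin-2-yl on this aromatic carbon, next to the ring nitrogen, gives an at least 160-fold higher number from compound 2 to compound 4 (2.20 log units; beyond the scatter), so the large step first seen with a phenyl group on the core also appears with a thiophen-3-yl group, and both steps run the same way: the same change on two cores in this assay, an 80-fold lower number (1.90 log units; beyond the scatter) from compound 1 to compound 3 and an at least 160-fold lower number (2.20 log units; beyond the scatter) from compound 4 to compound 2; the limit leaves it open whether they differ Thiophen-3-yl in place of phenyl, silent between compound 2 and compound 3, gives an at least 2.2-fold higher number from compound 1 to compound 4 (0.34 log units; beyond the scatter) when pyridin-3-yl occupies this position, so that swap does not stay within the scatter on both cores, although the comparison between the two steps remains unresolved: the same change on two cores in this assay, a 1.1-fold lower number (0.04 log units; within the scatter) from compound 2 to compound 3 and an at least 2.2-fold lower number (0.34 log units; beyond the scatter) from compound 4 to compound 1; the limit leaves it open whether they differ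

The compounds shown leave open how pyridin-4-yl, or a pyridin-2-yl group carrying an amine or a methyl group, would read at this position. They also leave open whether the remaining pyridin-2-yl group can take the same exchange, and how far the number for compound 4 actually lies from those of the other compounds.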